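The compounds below may be only part of what the source reports. "The series", "measured", "known", "first", "only" and "open" are said of these compounds alone.

Working notes on the trimethoxyphenyl series in a functional assay on PC-3 cells (Homo sapiens) for antiproliferative activity, read by MTT assay, tested at 5 uM; a higher number here means a stronger effect of the compound at the concentration tested, a lower number a weaker effect. Of the compounds shown here, three have numbers so far. Compound 1 `COc1cc(C(=O)N/N=C/c2ccc(F)c(F)c2)cc(OC)c1OC` gives 43.7%. Compound 3 `COc1cc(C(=O)N/N=C/c2cccc(C(F)(F)F)c2)cc(OC)c1OC` gives 79.8%. Compound 2 `COc1cc(C2=NN(C(C)=O)C(c3ccccc3C(F)(F)F)O2)cc(OC)c1OC`, which carries a 2-(trifluoromethyl)phenyl on the acetylated five-membered ring, gives 15.2%, the lowest of the three numbers: compound 1 stands higher by a margin beyond the scatter, and compound 3 higher still, also beyond the scatter. For the measured compounds named here, no pair among the three differs in only one place, so no single step can be read from the measured set.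

Compound 4 `COc1cc(C2=NN(C(C)=O)C(c3ccccc3F)O2)cc(OC)c1OC` follows from compound 2 by one change: fluoro in place of trifluoromethyl on an aromatic carbon. The two hydrazones do not share this ring and give no guidance on the size of the step. The expectation is a step of a number 1.2 percentage points lower from compound 2 to compound 4 (within the scatter) from compound 2 to compound 4 that stays within the scatter, in no firm direction. Compound 4 is therefore estimated at 14% in this assay, with a plausible range from 2% to 30%.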

Compound 4, a percentage reported as inhibition, at one concentration (the size of the read-out at that concentration, not a potency): 31.6%
Beside the measured number, compound 4's estimate is 17.6 percentage points below it; the whole stated range lies below it.
By their numbers in this assay, from the lowest: compound 2; then compound 4; then compound 1; then compound 3.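

In this assay, for the compounds shown here, fluoro in place of trifluoromethyl on an aromatic carbon ortho to a large group gives a number 16.4 percentage points higher from compound 2 to compound 4 (beyond the scatter) and is the only one-place step read so far. Going by these compounds alone, the number at this position therefore responds to the group it carries: the exchange of four heavy atoms for one changes the read-out by more than the usual scatter, which the earlier compounds, with no one-place pair among them, could not show. Nothing on hand accounts for the direction or size of this step.

On these data alone, a single step gives no trend across substituents, so it remains open how a bare hydrogen, a chloro, an amine or a carboxylic acid on the same carbon would compare. Also open, as far as these compounds go, is whether the same exchange gives a similar step at another carbon of this ring or on the hydrazone compounds.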